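The compounds below may be only part of what the source reports. "The series", "measured", "known", "first", "only" and "open" are said of these compounds alone.

Of the compounds shown here, two have numbers so far in a functional assay on LoVo cells (Homo sapiens) for inhibition; on this read-out higher numbers stand for weaker inhibition and lower numbers for stronger inhibition. Compound 1 `COc1ncnc2c(N[C@H]3O[C@H](CO)[C@@H](O)[C@H]3O)ncnc12` gives 18.7 uM, and compound 2 `Nc1ncnc2c(N[C@@H]3O[C@H](CO)[C@@H](O)[C@H]3O)ncnc12` gives 7 uM, the lower of the two numbers by a gap beyond the scatter. Compound 3 `COc1ncnc2c(N[C@@H]3O[C@H](CO)[C@@H](O)[C@H]3O)ncnc12` has not yet been measured in this assay. It departs from compound 2 in one place, with methoxy in place of amino on an aromatic carbon, next to the ring nitrogen: methoxy in place of amino on an aromatic carbon. For the measured compounds named here, no step between measured compounds is available to calibrate this change. Compound 1 also carries the methoxy and, at 18.7 uM, reads weaker than compound 2, so a moderate loss is the working expectation. The expected change is a 2.1-fold higher number from compound 2 to compound 3 (0.33 log units; beyond the scatter), toward weaker inhibition, with a size near the scatter or modestly beyond it. For compound 3 the estimated value is 15 uM, with an expected range of 6 uM to 40 uM.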

Compound 3, concentration for 50% inhibition: 0.28 uM
Beside the measured number, compound 3's estimate is 54-fold (1.73 log units) above it; the measured number lies below the stated range.
By their numbers in this assay, from the lowest: compound 3; then compound 2; then compound 1.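

In this assay, methoxy in place of amino on an aromatic carbon, next to the ring nitrogen, gives a 25-fold lower number from compound 2 to compound 3 (1.40 log units; beyond the scatter), so amino is not required at this position in this configuration, and methoxy reads far stronger there. Compound 1 therefore gave a misleading picture of the methoxy group, as the same group with the other configuration gives a 67-fold lower number from compound 1 to compound 3 (1.82 log units; beyond the scatter). This large gap between the two methoxy compounds can be assigned to the stereocentre at a saturated ring carbon, drawn S in compound 1 and R in compound 3, because of what separates the pair: the fact that compounds 1 and 3 differ only in the configuration as drawn

Open, on these data alone, is whether the step from amino to methoxy keeps its size with that stereocentre drawn S. Also open is how ethoxy, a longer ether, or dimethylamino would read at this position.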